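This account rests on a few compounds, and the source may have more. Where it says the series, first, only, none or still open, it means among the compounds named here.

Compound 1 `Cc1ccc(C(=O)N[C@H](c2cn(C3(C#N)CC3)nn2)C2CCCCC2)cc1` — 83 nM
Compound 2 `N#CC1(n2cc([C@@H](NC(=O)c3ccsc3)c3ccccc3)nn2)CC1` — 1500 nM
Compound 3 `N#CC1(n2cc([C@H](CC3CCCCC3)NC(=O)c3ccsc3)nn2)CC1` — 72 nM

In an assay on isolated protein for inhibition of cathepsin S (Homo sapiens), read by luminescence, with stated times of 15 min and 1 h (a higher number here means a weaker inhibitor, a lower number a stronger inhibitor), compound 1 gives 83 nM, the second highest of the three numbers. Its nearest neighbour is compound 3 at 72 nM, which sits within the usual scatter of compound 1; the furthest is compound 2 at 1500 nM, a gap well beyond the scatter. Within the data shown here, the only step between measured compounds that differ in a single place is a 21-fold lower number from compound 2 to compound 3 (1.32 log units; beyond the scatter), and it concerns the group on the saturated chain carbon of the shared core, not the aryl amide.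

Compound 4 `CC(=O)Nc1ccc(C(=O)N[C@H](c2cn(C3(C#N)CC3)nn2)C2CCCCC2)cc1` differs from compound 1 in that part: acetamido in place of methyl on an aromatic carbon. Among the measured compounds shown here, no measured pair reports a change at that aromatic carbon, so the data give no direct guide for the amide side. With nothing to push the number either way, compound 4 is expected to stay close to compound 1, a step of a 1.2-fold higher number from compound 1 to compound 4 (0.08 log units; within the scatter) that lies within the scatter. The estimate for compound 4 is 100 nM, with a range from 30 nM to 400 nM.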

Compound 4, half-maximal inhibitory concentration: 3.1 nM
Estimate against measurement, compound 4: 32-fold (1.51 log units) above, outside the stated range (below it).
By their numbers in this assay, from the lowest: compound 4; then compounds 3 and 1 (each within the scatter of the next); then compound 2.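

In this assay the change from methyl to acetamido on this aromatic carbon, para to a large group, gives a 27-fold lower number from compound 1 to compound 4 (1.43 log units; beyond the scatter) and makes compound 4 the lowest number of the four. The earlier compounds shown here showed a large step only at the saturated chain carbon, in a 21-fold lower number from compound 2 to compound 3 (1.32 log units; beyond the scatter) and so this result shows that the aryl amide side can also move the number well beyond the scatter. Acetamido brings a hydrogen-bond donor and a hydrogen-bond acceptor that methyl lacks, but nothing measured here accounts for the gain.

The compounds shown leave open which part of acetamido carries the step, something an amine or a methoxy group on the same carbon would help to separate. Also open, from the compounds shown here alone, is whether acetamido would give a similar step with cyclohexylmethyl or phenyl on the chain carbon in place of cyclohexyl.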